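Cytotoxicity When an Amide Replaces a Sulfamide

A few compounds are considered here, and "the series" means these few. Any claim that something is new, unique, unknown or untested is made for them only; others in the source may bear on it.

Three compounds share one core and differ only in a side group on a saturated chain carbon bound to a saturated ring carbon. In an ADME assay on L02 cells (Homo sapiens) for cytotoxicity, read by MTT assay, with a stated time of 48 h (a higher number here means a weaker inhibitor, a lower number a stronger inhibitor), compound 1 `O=C1CNC(=O)N1C[C@H]1CN(c2ccc(-n3cc(-c4ccccn4)cn3)c(F)c2)C(=O)O1` reaches only the limit of > 400 ug/mL. Compound 2 `O=C1CSC(=O)N1C[C@H]1CN(c2ccc(-n3cc(-c4ccccn4)cn3)c(F)c2)C(=O)O1` likewise reaches only the limit of > 400 ug/mL. There is a step that the two limits leave unreadable from compound 1 to compound 2 because of the limit of > 400 ug/mL in this assay, at which 2 of the 3 values shown sit. For the measured compounds named here, compound 3 `CN(C)S(=O)(=O)NC[C@H]1CN(c2ccc(-n3cc(-c4ccccn4)cn3)c(F)c2)C(=O)O1` is the only one with a plain number, giving 158 ug/mL in this assay; the steps of an at least 2.5-fold lower number from compound 1 to compound 3 (0.40 log units; beyond the scatter) and an at least 2.5-fold lower number from compound 2 to compound 3 (0.40 log units; beyond the scatter) both run lower, beyond the scatter. Compound 4 `O=C1O[C@@H](CNC(=O)C(F)(F)F)CN1c1ccc(-n2cc(-c3ccccn3)cn2)c(F)c1` carries (trifluoromethyl)carbonyl in place of dimethylsulfamoyl on an amine nitrogen. Going by the values given here, no measured step removes the (dimethylsulfamoyl)amino group, so the two measured steps toward compound 3 show only that this group gave the lower number; they give no direction for replacing it with a chain amide. The step of a 1.4-fold higher number from compound 3 to compound 4 (0.14 log units; within the scatter) is therefore expected to stay within the scatter. Compound 4 is estimated at 220 ug/mL, between 90 ug/mL and 500 ug/mL, with a fair chance that only a limit is reported.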

Compound 4, half-maximal inhibitory concentration: > 400 ug/mL
Compound 4: no number, only a limit; the forecaster's own chance of this, stated with the estimate: 40%; middle value at least 1.8-fold (0.25 log units) away from the limit.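

In this assay, putting (trifluoromethyl)carbonyl in place of dimethylsulfamoyl on the amine nitrogen gives an at least 2.5-fold higher number from compound 3 to compound 4 (0.40 log units; beyond the scatter). The earlier steps shown here showed the lower number only against the two ring groups, 2,5-dioxoimidazolidin-1-yl and 2,4-dioxo-1,3-thiazolidin-3-yl, whereas this one shows that an open chain group on the same amine nitrogen does not by itself keep that lower number, leaving compound 3 alone with a plain value. The steps from compound 1 and compound 2 to compound 4 cannot be read, because all three values are limits and not numbers: the limit of > 400 ug/mL in this assay, at which 3 of the 4 values shown sit.

Going by these compounds, what remains open is whether the higher number goes with the carbonyl or with the trifluoromethyl. An acetyl group or a simple free amine at this nitrogen would help to separate the two.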